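Unbound fraction after loss of ethylamino from compound 2

The compounds below may be only part of what the source reports. "The series", "measured", "known", "first", "only" and "open" are said of these compounds alone.

Measured in an ADME assay on a cell-free system (plasma, Rattus norvegicus) for protein binding:
- compound 1 `CNc1nccc(N2CC[C@H](NC(=O)Nc3ccc(CN4CCC4)c(C(F)(F)F)c3)C2)n1`: 89.2%
- compound 2 `CCNc1nccc(N2CC[C@H](NC(=O)Nc3ccc(Cl)c(C(F)(F)F)c3)C2)n1`: 99.9%
- compound 3 `CNc1nccc(N2CC[C@H](NC(=O)Nc3ccc(OC(F)F)cc3)C2)n1`: 97.7%

Compound 2 has the lowest unbound fraction of the three, at 99.9%. Its gaps to compound 3 and to compound 1 both lie beyond the scatter.

Compound 4 `O=C(Nc1ccc(Cl)c(C(F)(F)F)c1)N[C@H]1CCN(c2ccncn2)C1` is the next compound to be read in this assay. Its difference from compound 2 is hydrogen in place of ethylamino on an aromatic carbon, a position between two ring nitrogen atoms.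

Within the data shown here, no measured pair isolates this change, so the data give no direct precedent for its size. The three values show only that binding varies well beyond the scatter across these structures. Compound 2 also sits near the top of the scale at 99.9%, which leaves little room for movement towards stronger binding. A move towards a larger unbound fraction, beyond the scatter, is therefore expected, though with wide uncertainty.

The estimated change is a 20-fold higher unbound fraction from compound 2 to compound 4 (1.30 log units; beyond the scatter).

For compound 4 the estimated value is 98%, with an expected range of 93% to 99.6%.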

Compound 4, plasma protein binding: 99.4%
Beside the measured number, compound 4's estimate is 3.3-fold (0.52 log units) (unbound fraction) above it, within the range that was stated.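

In this assay, among these compounds, hydrogen in place of ethylamino on the aromatic carbon between two ring nitrogen atoms gives a 6.0-fold higher unbound fraction from compound 2 to compound 4 (0.78 log units; beyond the scatter), the first step that isolates a single change. This position therefore registers in the read-out even when binding is close to the top of the scale, although the step is modest. Ethylamino is also not needed for high binding in this pair, as compound 4 still reads 99.4% in this assay without it, and no measurement shown accounts for the size of the step.

This remains a single pair, carrying the same chloro and trifluoromethyl substitution on both compounds, so it cannot be said whether the step would keep its size on the other urea substituents, such as those of compound 1 and compound 3. The compounds shown also leave open how a primary amine, a methoxy group or a longer chain such as butylamino on this carbon would compare with ethylamino and hydrogen, and so whether the size of the group or some other feature of it tracks with the unbound fraction.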